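Adding a methoxy group: tolerance in bovine kidney cells

The compounds below may be only part of what the source reports. "The series", "measured", "known", "first", "only" and "open" are said of these compounds alone.

Compound 1 `COc1ccc(-c2nc3cc(/C(C)=N/O)ccc3[nH]2)c(OC)c1` and compound 2 `COc1ccc(-c2nc3cc(/C(C)=N/O)ccc3[nH]2)c(OC)c1OC` share one core; compound 3 `COc1ccc(-c2nc3cc(/C(C)=N/NC(N)=O)ccc3n2C2CCCCC2)cc1` and the not yet measured compound 4 `COc1ccc(-c2nc3cc(/C(C)=N/NC(N)=O)ccc3n2C2CCCCC2)c(OC)c1` share another. The difference between the two cores is not broken down here. In an ADME assay on MDBK cells (Bos taurus) for cytotoxicity, read by MTT assay, with a stated time of 96 h (a lower number here means that less compound is tolerated, a higher number that more compound is tolerated), compound 1 gives only a limit of the assay, > 100000 nM. Compound 2 likewise gives only a limit, > 100000 nM. For the measured compounds named here, compound 3 gives 54000 nM, the single number so far. The change from compound 1 to compound 2 is methoxy in place of hydrogen on an aromatic carbon; its step is a step that the two limits leave unreadable from compound 1 to compound 2, because of the limit of > 100000 nM in this assay, at which 2 of the 3 values shown sit. From compound 3 to compound 4 the same kind of change is made, (methoxy in place of hydrogen on an aromatic carbon), though here the methoxy enters ortho to a large group and meta to a methoxy group, rather than ortho to two methoxy groups and meta to a large group. With no readable step to lean on, the expected step is a 1.1-fold higher number from compound 3 to compound 4 (0.05 log units; within the scatter). Compound 4 is therefore expected near 60000 nM.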

Compound 4, half-maximal cytotoxic concentration: 36000 nM
For compound 4 the middle estimate is 1.7-fold (0.22 log units) above the measured one, within the range that was stated.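

In this assay, placing the methoxy group on the core of compound 3 gives a 1.5-fold lower number from compound 3 to compound 4 (0.18 log units; within the scatter), so on this core the change cannot be told apart from ordinary repeat variation. On the core of compound 1 the same kind of change cannot be read, because compound 1 and compound 2 both give only a limit of the assay: the limit of > 100000 nM in this assay, at which 2 of the 4 values shown sit. One readable pair therefore shows no clear shift on a single core, but it does not show that the change carries over between cores, particularly as the methoxy enters at a different place on each.

Still open, from the compounds shown here alone, is whether an amine or a carboxylic acid in place of the methoxy would give a step beyond the scatter. Also open, going by these compounds, is how the core of compound 1 responds at concentrations where the assay returns actual numbers.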